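Thiazole acetic acids: phenoxy to phenylsulfanyl at the chain carbon

The source may hold more compounds than are shown below. What is called first, only, known or untested is meant among the compounds shown, and "the series" means these compounds.

Measured compounds:
compound 1, `O=C(O)Cc1sc(Cc2ccccc2)nc1-c1ccc(Cl)cc1`, 50%
compound 2, `O=C(O)Cc1sc(COc2ccc(Cl)cc2)nc1-c1ccc(Cl)cc1`, 50%

In an in vitro functional assay on HEK285-7 cells for antagonist activity at prostaglandin D2 receptor 2 (Homo sapiens), read by BRET and beta-arrestin recruitment (a higher number here means a larger maximal response, a lower number a smaller maximal response), compound 1 gives 50% and compound 2 gives 50%. Among the compounds with values here, the one measured step, no change at the digits printed from compound 1 to compound 2 (within the scatter), shows that exchanging phenyl for 4-chlorophenoxy at the saturated chain carbon bound to an aromatic carbon left the maximal response where it was. Compound 2 therefore stands level with compound 1 in this assay.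

Compound 3, `O=C(O)Cc1sc(CSc2ccccc2)nc1-c1ccc(Cl)cc1`, is not yet measured. Its difference from compound 2 is phenylsulfanyl in place of 4-chlorophenoxy on a saturated chain carbon bound to an aromatic carbon. The same position is varied as in the measured step, and that step lay within the scatter, so a phenylsulfanyl group there is expected to behave alike. The step of no change at the digits printed from compound 2 to compound 3 (within the scatter) is therefore expected to stay within the scatter. For compound 3 in this assay the estimate is 50%, with a range from 35% to 65%.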

Compound 3, largest response reached (reported as efficacy), in percent of the reference or control that the assay uses: 50%
The estimate for compound 3 equals the measured number at the digits printed; the measured number falls inside the stated range.
By their numbers in this assay, from the lowest: compounds 1, 2 and 3 (each within the scatter of the next).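

In this assay, the record gives no change at the digits printed from compound 2 to compound 3 (within the scatter) and also no change at the digits printed from compound 1 to compound 3 (within the scatter) for the exchange on the saturated chain carbon bound to an aromatic carbon. The earlier pair had compared only phenyl and 4-chlorophenoxy; phenylsulfanyl now adds a sulfur link and carries no chlorine, and all three compounds still stand level in this read-out, so this position has tolerated each of these aromatic groups alike. No supporting data bear on why the maximal response stays the same across them.

All the groups shown at this place carry a six-membered aromatic ring of carbon only, so what an amine, a carboxylic acid or a longer chain would do there remains open. No group yet shown moves the response beyond the scatter, so what this position can change in the read-out is also unknown.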